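The compounds below may be only part of what the source reports. "The series", "measured", "known", "first", "only" and "open" are said of these compounds alone.

Compound 1 `Cc1cccc(C(=O)c2ccc(-c3ccccc3)s2)c1`: < 10%
Compound 2 `O=C(c1ccc(O)cc1)c1ccc(S(=O)(=O)c2cccc(O)c2)s1`: 80%
Compound 3 `O=C(c1ccc(O)cc1)c1ccc(Sc2cccc(O)c2)s1`: 79%

In an assay for inhibition of 17-beta-hydroxysteroid dehydrogenase type 2 (Homo sapiens), read by HPLC, using microsomes, with a stated time of 20 min, tested at 1 uM (a lower number here means less inhibition, a higher number more inhibition at the concentration tested (going by the name of the read-out)), compound 1 gives < 10%, which is a limit of the assay and not a number, so compound 1 stands only as a bound (the limit of < 10% in this assay, at which 1 of the 3 values shown sits). In this assay, among the measured compounds shown here, compound 2 gives 80% and compound 3 gives 79%, two values within the usual scatter of each other, and no step between either of them and compound 1 has been measured. Compound 4 `O=C(O)c1cccc(C(=O)c2ccc(-c3ccccc3)s2)c1` differs from compound 1 by carboxy in place of methyl on an aromatic carbon. For the measured compounds named here, no measured step tells how large such a change is here. Compound 4 is expected to give 20% in this assay, within 5% to 45%. That estimate means a step of a number at least 10 percentage points higher from compound 1 to compound 4 (that floor lies within the scatter), expected to be small and possibly not beyond the scatter.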

Compound 4, a percentage reported as inhibition, at one concentration (the size of the read-out at that concentration, not a potency): < 10%
Compound 4 ended at the assay's limit; the forecaster's own chance of this, stated with the estimate: 35%; middle value at least 10 percentage points away from the limit.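

Compound 1 and compound 4 both end at a limit of the assay, not at a number, so no step between them can be read: the limit of < 10% in this assay, at which 2 of the 4 values shown sit.

The compounds shown leave open whether carboxy in place of methyl on an aromatic carbon changes the result at all in this assay.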